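From 3,5-dichlorophenyl to 3,5-dimethylphenyl on a sulfonyl sulfur

The source may report more compounds than this note shows. Statements on the series, on what has been measured and on what is new or still open speak of the compounds shown alone.

Measured in an ADME assay on MT4 cells (Homo sapiens) for cytotoxicity, with a stated time of 5 days; on this read-out higher numbers stand for lower toxicity in this test and lower numbers for higher toxicity in this test:
- Compound 1 `O=C(CCl)Nc1ccc(Cl)cc1NS(=O)(=O)c1cc(F)cc(F)c1`: 179000 nM
- Compound 2 `O=C(CCl)Nc1ccc(Cl)cc1NS(=O)(=O)c1cc(Cl)cc(Cl)c1`: > 291000 nM (a limit)

Compound 2 stands at > 291000 nM, which is a limit of the assay and not a number. Compound 3 `Cc1cc(C)cc(S(=O)(=O)Nc2cc(Cl)ccc2NC(=O)CCl)c1` is not yet measured, and it differs from compound 2 as follows: 3,5-dimethylphenyl in place of 3,5-dichlorophenyl on a sulfonyl sulfur. Within the data shown here, the only measured step at this place is an at least 1.6-fold higher number from compound 1 to compound 2 (0.21 log units; that floor lies within the scatter). On that step alone, no change beyond the scatter is expected in this assay, in either direction. The expected step is an at least 1.1-fold lower number from compound 2 to compound 3 (0.04 log units; that floor lies within the scatter). Compound 3 is estimated at 260000 nM, with an expected range from 130000 nM to 420000 nM.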

Compound 3, half-maximal cytotoxic concentration: 35100 nM
Compound 3: the middle estimate sits 7.4-fold (0.87 log units) above what was measured, outside the stated range (below it).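

In this assay, the group on the sulfonyl sulfur proves able to shift the number well beyond the scatter: 3,5-dimethylphenyl gives an at least 8.2-fold lower number from compound 2 to compound 3 (0.91 log units; beyond the scatter) and a 5.1-fold lower number from compound 1 to compound 3 (0.71 log units; beyond the scatter). The earlier step between the two halogen-bearing groups had a floor within the scatter, so it gave no sign of a shift of this kind. The value of compound 2 is a limit of the assay and not a number, so the step from it is only a floor: the limit of > 291000 nM in this assay, at which 1 of the 3 values shown sits.

The compounds shown leave open whether a methoxy group or an amine in place of the two methyl groups would give a number as low as that of compound 3.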